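Deoxyribose-linked series, substituent on the aromatic core

The compounds below may be only part of what the source reports. "The series", "measured", "known", "first", "only" and "open" are said of these compounds alone.

Measured compounds in a functional assay on EL4 cells (Mus musculus) for inhibition, tested at 100 uM; on this read-out higher numbers stand for more inhibition at the one concentration tested (going by the name of the read-out) and lower numbers for less inhibition:
compound 1, `OC[C@H]1O[C@@H](n2cnc3c(NCc4ccccc4)nccc32)C[C@@H]1O`: 8%
compound 2, `OC[C@H]1O[C@@H](n2cnc3c(S)nccc32)C[C@@H]1O`: < 5%
compound 3, `OC[C@H]1O[C@@H](n2cnc3c(Cl)nccc32)C[C@@H]1O`: < 5%

Compound 3 carries chloro on the shared core. In this assay compound 3 reports only a limit, < 5%, not a number. Compound 2 likewise reports only a limit, < 5%. Compound 1 gives 8%. The step of a number at least 3 percentage points lower from compound 1 to compound 3 (that floor lies within the scatter) is within the scatter, so on the numbers shown the inhibition in this assay is level across the series, with two of the three values sitting at the limit of < 5% in this assay, at which 2 of the 3 values shown sit.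

Compound 4, `CSc1nccc2c1ncn2[C@H]1C[C@H](O)[C@@H](CO)O1`, differs from compound 3 by methylsulfanyl in place of chloro on an aromatic carbon. The closest measured step is a step that the two limits leave unreadable from compound 2 to compound 3, which two limits make unreadable. The steps of a number at least 3 percentage points lower from compound 1 to compound 2 (that floor lies within the scatter) and a number at least 3 percentage points lower from compound 1 to compound 3 (that floor lies within the scatter) show that exchanging the group at this position has so far moved this assay only within scatter, toward the limit. A step within the scatter, a number no lower from compound 3 to compound 4 (the limit leaves the size open), is therefore expected. Compound 4 is expected to give about 5%, in the range 0% to 15%, most likely again only a limit.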

Compound 4, a percentage reported as inhibition, at one concentration (the size of the read-out at that concentration, not a potency): < 5%
Compound 4: only a limit was reported; the forecaster's own chance of this, stated with the estimate: 60%; the middle value lies on the limit itself.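

In this assay, methyl on the sulfur of compound 2 and methylsulfanyl in place of the chloro of compound 3 both lead to a limit, so neither step to compound 4 can be read. Among these compounds, the one readable step is a number at least 3 percentage points lower from compound 1 to compound 4 (that floor lies within the scatter), so on these numbers methylsulfanyl is not separated from benzylamino, just as sulfanyl and chloro were not. Adding a methyl on the sulfur therefore brings no reading above the limit, and the series gathers further at that limit: the limit of < 5% in this assay, at which 3 of the 4 values shown sit.

Going by these compounds, whether an unsubstituted amine or a carboxylic acid on this aromatic carbon would give a value clear of the limit and the scatter stays open. Also open, on these data alone, is whether a longer chain on the sulfur would give a readable number in this assay.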